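A few compounds are considered here, and "the series" means these few. Any claim that something is new, unique, unknown or untested is made for them only; others in the source may bear on it.

Of the compounds shown here, three have so far been measured in a functional assay on BJAB cells (Homo sapiens) for antiproliferative activity, with a stated time of 4 days; a lower number here means that less compound is needed, a higher number that more compound is needed for the effect. Compound 1 `Cc1cc(Cl)cc(-c2c(C)nn(-c3nc(-c4ccc(Cl)c(Cl)c4)c(SC(C)C)s3)c2C(=O)O)c1` gives 663 nM, the lowest of the two numbers reported. Compound 3 `Cc1nn(-c2nc(-c3ccc(Cl)c(Cl)c3)c(SC(C)C)s2)c(C(=O)O)c1-c1cc(C(F)(F)F)cc(C(F)(F)F)c1` gives 1800 nM, a higher number than compound 1 that lies beyond the usual scatter. Compound 2 `Cc1c(-c2cc(Cl)cc(Cl)c2)c(C(=O)O)nn1-c1nc(-c2ccncc2)c(SC(C)C)s1` is recorded in this assay as "not active" (no number reported), without a number. Compound 4 `Cc1cc(-c2c(C)nn(-c3nc(-c4ccc(Cl)c(Cl)c4)c(SC(C)C)s3)c2C(=O)O)cc(C)n1` has not yet been measured; it differs from compound 1 in a single place: 2,6-dimethylpyridin-4-yl in place of 3-chloro-5-methylphenyl on an aromatic carbon. Among the compounds with values here, no measured pair shows this same exchange, so its effect can only be guessed. A moderate rise in the number, beyond the scatter, is expected for the step of a 3.0-fold higher number from compound 1 to compound 4 (0.48 log units; beyond the scatter). Compound 4 is therefore estimated at 2000 nM, within a range from 600 nM to 8000 nM.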

Compound 4, half-maximal effective concentration: 580 nM
Compound 4: middle estimate off by 3.4-fold (0.54 log units), on the high side; the whole stated range lies above it.
By their numbers in this assay, from the lowest: compounds 4 and 1 (each within the scatter of the next); then compound 3.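

In this assay, replacing 3-chloro-5-methylphenyl with 2,6-dimethylpyridin-4-yl gives a 1.1-fold lower number from compound 1 to compound 4 (0.06 log units; within the scatter), so this position tolerates a ring nitrogen, and a chlorine on this ring is not needed for a number in this range. No measurement shown explains why the two groups read alike. From the compounds shown here alone, it remains open whether a pyridin-4-yl group without its two methyl groups would read the same at this position, or whether an amine or a methoxy group on the ring would keep the number in this range.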